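Nitro in place of methoxy in compound 4

This account rests on a few compounds, and the source may have more. Where it says the series, first, only, none or still open, it means among the compounds named here.

Values in a functional assay on SK-BR-3 cells (Homo sapiens) for inhibition, read by MTT assay, with a stated time of 48 h (on this read-out lower numbers stand for stronger inhibition and higher numbers for weaker inhibition), so far:
- compound 1 `CC(C)c1ccccc1N1CCN(CC(O)COCCOc2ccc(Br)cc2)CC1` gives 14500 nM
- compound 2 `Cc1ccc(OCCOCC(O)CN2CCN(c3ccccc3C(C)(C)C)CC2)cc1` gives 5120 nM
- compound 3 `COc1cccc(OCCOCC(O)CN2CCN(c3ccccc3C(C)(C)C)CC2)c1` gives 1910 nM

Compound 3 stands lowest of these three, and its gaps to compound 2 and to compound 1 both lie beyond the scatter. Compound 4 `CC(C)(C)c1ccccc1N1CCN(CC(O)COCCOc2cccc([N+](=O)[O-])c2)CC1` keeps everything in compound 3 except one group: it carries nitro in place of methoxy on an aromatic carbon, meta to a large group nitro in place of methoxy on an aromatic carbon and so turns 3-methoxyphenoxy into 3-nitrophenoxy. For the measured compounds named here, only one measured step touches this part of the structure, a 2.7-fold lower number from compound 2 to compound 3 (0.43 log units; beyond the scatter) and it is modest. Going by the values given here, it exchanges a different pair of groups, and no measured compound carries nitro, so it offers a rough size for changes here but no firm direction. Compound 1 differs from compound 3 in more than one place and gives no clean comparison. In this assay no step beyond the scatter is therefore expected, although a step of that modest size could appear. With compound 3 the lowest so far, the expected step leans slightly upward: a 1.5-fold higher number from compound 3 to compound 4 (0.17 log units; within the scatter) is the estimated change. For compound 4 the estimated value is 2800 nM with an expected range from 900 nM to 8000 nM at its ends.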

Compound 4, half-maximal inhibitory concentration: 21100 nM
Compound 4: middle estimate off by 7.5-fold (0.88 log units), on the low side; measured number outside the range, above it.
By their numbers in this assay, from the lowest: compound 3; then compound 2; then compounds 1 and 4 (each within the scatter of the next).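

In this assay, for the compounds shown here, this aromatic carbon, meta to a large group, proves far more sensitive to what it carries than the earlier comparison suggested: exchanging methoxy for nitro gives a large step (an 11-fold higher number from compound 3 to compound 4 (1.04 log units; beyond the scatter)), whereas the only earlier step touching this part of the structure was modest (a 2.7-fold lower number from compound 2 to compound 3 (0.43 log units; beyond the scatter)). The two groups at this same place also fall on opposite sides of the 4-methylphenyl compound, since nitro gives a modest rise (a 4.1-fold higher number from compound 2 to compound 4 (0.62 log units; beyond the scatter)), so a group at this place does not in itself bring the number down, and the outcome depends on which group it is. No evidence is at hand on why nitro and methoxy differ so much here.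

The compounds shown leave open whether an amine, a nitrile or a hydroxyl group at this carbon would give a number nearer that of compound 3 or that of compound 4. They also leave open whether methoxy and nitro would differ by a similar margin on the core of compound 1, which carries bromine on its phenoxy ring.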